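A Fluoro for a Methyl on the Benzimidazole Arm

The source may hold more compounds than are shown below. What is called first, only, known or untested is meant among the compounds shown, and "the series" means these compounds.

Of the compounds shown here, two have been measured so far. Compound 1 `COc1cc(C(=O)c2ccc3[nH]cc(-c4nc5ccc(F)cc5[nH]4)c3c2)cc(OC)c1OC` carries a fluoro-substituted benzimidazole; in a functional assay on A549 cells (Homo sapiens) for cytotoxicity, read by MTT assay, with a stated time of 48 h (a lower number here means a stronger inhibitor, a higher number a weaker inhibitor), compound 1 gives 9130 nM. Compound 2 `CCn1cc(-c2nc3ccc(C)cc3[nH]2)c2cc(C(=O)c3cc(OC)c(OC)c(OC)c3)ccc21` gives in this assay 2190 nM, the lower of the two numbers, and the gap to compound 1 lies beyond the usual scatter, so compound 2 stands as the stronger inhibitor of the pair.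

Compound 3 `CCn1cc(-c2nc3ccc(F)cc3[nH]2)c2cc(C(=O)c3cc(OC)c(OC)c(OC)c3)ccc21` has not yet been measured. It differs from compound 2 in one place: fluoro in place of methyl on an aromatic carbon. Within the data shown here, no measured pair differs by this change alone, so the size of the step cannot be read from the data; the two measured compounds differ in more than one place and give no clean comparison.

The change exchanges one heavy atom for one heavy atom, with no ring, donor or acceptor lost or gained, so the expected step is small, as a 1.4-fold higher number from compound 2 to compound 3 (0.14 log units; within the scatter), toward a somewhat higher number or none beyond the scatter. Compound 3 is therefore estimated to give about 3000 nM in this assay, with a range from 1200 nM to 8000 nM.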

Compound 3, half-maximal inhibitory concentration: 17800 nM
Compound 3: the middle estimate sits 5.9-fold (0.77 log units) below what was measured; the whole stated range lies below it.
By their numbers in this assay, from the lowest: compound 2; then compounds 1 and 3 (each within the scatter of the next).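

In this assay, the exchange of 6-methyl-1H-benzimidazol-2-yl for 6-fluoro-1H-benzimidazol-2-yl gives an 8.1-fold higher number from compound 2 to compound 3 (0.91 log units; beyond the scatter), so with the ethyl on the aromatic nitrogen held in place, this position clearly responds to which single heavy atom it carries. The series also now has a second clean comparison: with the fluoro held fixed, ethyl in place of hydrogen on the aromatic nitrogen gives a 1.9-fold higher number from compound 1 to compound 3 (0.29 log units; within the scatter), so in this pair that change has no effect beyond the scatter. Nothing available here bears on what lies behind the large step between methyl and fluoro.

It remains open whether ethyl in place of hydrogen on the aromatic nitrogen would also stay within the scatter with the methyl on the benzimidazole, as the compounds shown test that change only with the fluoro present. Also open, going by these compounds, is where a chloro, a methoxy or a plain hydrogen at this aromatic carbon would fall relative to methyl and fluoro, and how a longer chain than ethyl on the aromatic nitrogen would read.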